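The compounds below may be only part of what the source reports. "The series", "measured", "known", "first", "only" and "open" are said of these compounds alone.

Within the data shown here, compound 1 `Cc1cc(O)ccc1C1=NN(c2ccc(S(C)(=O)=O)cc2)C(=O)CC1` gives 52.6% in a functional assay on the whole organism (strain Wistar) for inhibition, with Rattus norvegicus as the target, read by paw edema, with stated times of 30 min and 5 h, at a dose of 0.05 mmol/kg by the oral route (a higher number here means more inhibition at the dose given (going by the name of the read-out), a lower number less inhibition), the second highest of the three numbers known here. Compound 3 `COc1ccc(C2=NN(c3ccc(S(C)(=O)=O)cc3)C(=O)CC2)cc1OC` reaches 82.4% in this assay, beyond the scatter above compound 1, while compound 2 `CS(=O)(=O)c1ccc(N2N=C(c3ccc(-c4ccccc4)cc3)CCC2=O)cc1` gives only 21% in this assay, beyond the scatter below it. No two of these measured compounds differ in a single place, so no single step can be read from them.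

Compound 4 `Cc1ccc(O)c(C2=NN(c3ccc(S(C)(=O)=O)cc3)C(=O)CC2)c1` is the untested one, differing from compound 1 only in how the same atoms are joined: 2-hydroxy-5-methylphenyl in place of 4-hydroxy-2-methylphenyl on a carbon with a double bond to nitrogen. Among the measured compounds shown here, with no comparable step to lean on, the expected change from compound 1 to compound 4 in this assay is a slight fall, within the scatter, of a number 7.6 percentage points lower from compound 1 to compound 4 (within the scatter). Compound 4 is therefore estimated at 45%, between 25% and 65%.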

Compound 4, a percentage reported as inhibition, in the whole organism at one dose (the size of the read-out at that dose, not a potency): 86.8%
Compound 4: middle estimate off by 41.8 percentage points, on the low side, outside the stated range (above it).
By their numbers in this assay, from the lowest: compound 2; then compound 1; then compounds 3 and 4 (each within the scatter of the next).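

Swapping 4-hydroxy-2-methylphenyl for 2-hydroxy-5-methylphenyl on a carbon with a double bond to nitrogen gives a number 34.2 percentage points higher from compound 1 to compound 4 (beyond the scatter) in this assay, with no atom gained or lost. The number at this position therefore depends on how the hydroxyl and methyl are arranged on the phenyl ring, not only on which atoms are present. Nothing measured here says why this step is so large. As far as these compounds go, it remains open whether the hydroxyl or the methyl carries the step, and whether an amine or a carboxylic acid in place of the hydroxyl would keep the number.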